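Compound 1 and an untested triazole exchange

The source may report more compounds than this note shows. Statements on the series, on what has been measured and on what is new or still open speak of the compounds shown alone.

Among the measured compounds shown here, in an ADME assay on the whole organism (Mus musculus, strain BALB/c) for pharmacokinetics, read by LC-MS, with a stated time of 24 h, at a dose of 10 mg/kg by the oral route (on this read-out higher numbers stand for higher oral bioavailability and lower numbers for lower oral bioavailability), compound 1 `Cn1nccc1-c1cc(C(F)(F)F)ccc1[C@H]1CCOc2cc(S(=O)(=O)Nc3nccs3)ccc21` gives 68% and is the lower of the two compounds measured so far, while compound 2 `Cn1nccc1-c1cc(C(F)(F)F)ccc1[C@H]1CCOc2cc(S(=O)(=O)Nc3ncccn3)ccc21` gives 89% as the only other number. Compound 3 `O=S(=O)(Nc1nccs1)c1ccc2c(c1)OCC[C@@H]2c1ccc(C(F)(F)F)cc1-n1ccnn1` keeps the 1,3-thiazol-2-yl of compound 1 on the sulfonamide nitrogen and differs in one group: 1H-1,2,3-triazol-1-yl in place of 1-methyl-1H-pyrazol-5-yl on an aromatic carbon in all, 1H-1,2,3-triazol-1-yl in place of 1-methyl-1H-pyrazol-5-yl on an aromatic carbon. That carbon belongs to a six-membered aromatic ring of carbon only, ortho to a large group and meta to a trifluoromethyl group. For the measured compounds named here, the single measured step, a number 21 percentage points higher from compound 1 to compound 2 (beyond the scatter) for pyrimidin-2-yl in place of 1,3-thiazol-2-yl on a sulfonamide nitrogen, lies at another place and bears on this change only indirectly. It gives a rough size for one exchange of groups, but no direction here. No step beyond the usual scatter is therefore expected, and the estimated step is a number 3 percentage points lower from compound 1 to compound 3 (within the scatter) with wide uncertainty. For compound 3 the expected value is 65% within an estimated range from 42% to 85% in this assay for now.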

Compound 3, oral bioavailability: 79%
The estimate for compound 3 lay 14 percentage points below the measured number; the range from low to high includes it.
By their numbers in this assay, from the lowest: compound 1; then compounds 3 and 2 (each within the scatter of the next).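

The step at this place is a number 11 percentage points higher from compound 1 to compound 3 (beyond the scatter) in this assay, with 1H-1,2,3-triazol-1-yl in place of 1-methyl-1H-pyrazol-5-yl and the 1,3-thiazol-2-yl on the sulfonamide nitrogen left unchanged. The earlier pair showed only a change on the sulfonamide nitrogen, a number 21 percentage points higher from compound 1 to compound 2 (beyond the scatter), so the aromatic carbon ortho to a large group and meta to a trifluoromethyl group is now a second place where one exchange of groups moves oral bioavailability beyond the scatter. Nothing at hand explains the step at this aromatic carbon.

The compounds shown do not separate the exchange of ring from the loss of the methyl group, so a plain pyrazole or a methyl-substituted triazole at this carbon could still divide the step between the two. On these data alone, it also remains open whether the triazole exchange carries over to the pyrimidin-2-yl series, and how a morpholine or a carboxylic acid at the same place would read in this assay.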